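The source may report more compounds than this note shows. Statements on the series, on what has been measured and on what is new or still open speak of the compounds shown alone.

Measured compounds:
- compound 1, `CC(C)[C@@H]1CC[C@@H](C)C[C@@]12N(C)C(=O)[C@@H]1[C@H]3C(=O)N(C)C(=O)[C@H]3ON12`: 39.2%
- compound 2, `COc1ccc(N2C(=O)[C@H]3[C@H](ON4[C@@H]3C(=O)N(C)[C@@]43C[C@H](C)CC[C@H]3C(C)C)C2=O)cc1`: 48.9%
- compound 3, `Cc1cccc(N2C(=O)[C@H]3[C@H](ON4[C@@H]3C(=O)N(C)[C@@]43C[C@H](C)CC[C@H]3C(C)C)C2=O)c1`: 16.1%

In a functional assay, read by spectrophotometry, with a stated time of 2 h, tested at 0.5 mg/mL (on this read-out higher numbers stand for a stronger effect at the one concentration tested and lower numbers for a weaker effect), compound 3 stands lowest of the three. Its value lies beyond the scatter of compound 1 (a number 23.1 percentage points lower from compound 1 to compound 3 (beyond the scatter)) and of compound 2 (a number 32.8 percentage points lower from compound 2 to compound 3 (beyond the scatter)), while a number 9.7 percentage points higher from compound 1 to compound 2 (within the scatter) stays within it. Compound 4, `Cc1ccc(N2C(=O)[C@H]3[C@H](ON4[C@@H]3C(=O)N(C)[C@@]43C[C@H](C)CC[C@H]3C(C)C)C2=O)c(C)c1`, differs from compound 3 in one place: 2,4-dimethylphenyl in place of 3-methylphenyl on an amide-type nitrogen in a ring. Among the measured compounds shown here, no measured step changes one aryl group for another aryl group bearing a different pattern of methyl substituents; the nearest guide, from compound 2 to compound 3, shows that such aryl changes can move this assay substantially. Compound 4 is therefore expected to sit near compound 3, with a number 7.9 percentage points higher from compound 3 to compound 4 (within the scatter), and its estimated value is 24%, in a range from 8% to 45%.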

Compound 4, a percentage reported as activity, at one concentration (the size of the read-out at that concentration, not a potency): 52.9%
Estimate against measurement, compound 4: 28.9 percentage points below; the measured number lies above the stated range.
By their numbers in this assay, from the lowest: compound 3; then compounds 1, 2 and 4 (each within the scatter of the next, the first and the last beyond it).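

In this assay, the group on this amide-type nitrogen proves highly sensitive to the pattern of methyl groups on the phenyl ring (a number 36.8 percentage points higher from compound 3 to compound 4 (beyond the scatter)). The 2,4-dimethylphenyl group stands level with 4-methoxyphenyl (a number 4 percentage points higher from compound 2 to compound 4 (within the scatter)) and above methyl (a number 13.7 percentage points higher from compound 1 to compound 4 (beyond the scatter)), so among the aryl compounds only compound 3 falls beyond the scatter below compound 1. From the compounds shown here alone, whether a phenyl ring carrying an amine or a carboxylic acid, or a longer chain in place of the ring, would hold this level remains open. Nothing available accounts for the gap between the two methyl-bearing phenyl groups.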